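From amino to acetamido: compound 3 to compound 4

A few compounds are considered here, and "the series" means these few. Any claim that something is new, unique, unknown or untested is made for them only; others in the source may bear on it.

- Compound 1 `Cc1ccc(NC(=O)NCCCCC(c2ccc(F)cc2)c2ccc(F)cc2)cc1`: > 20000 nM (a limit)
- Compound 2 `O=C(NCCCCC(c1ccc(F)cc1)c1ccc(F)cc1)Nc1ccc([N+](=O)[O-])cc1`: 6470 nM
- Compound 3 `Nc1ccc(NC(=O)NCCCCC(c2ccc(F)cc2)c2ccc(F)cc2)cc1`: > 20000 nM (a limit)

All three were tested in a functional assay on MDA-MB-231 cells (Homo sapiens) for cytotoxicity, read by MTT assay, with a stated time of 48 h; on this read-out lower numbers stand for stronger inhibition and higher numbers for weaker inhibition. There, compound 3 gives no number, only the limit > 20000 nM. Across the set the position is the limit of > 20000 nM in this assay, at which 2 of the 3 values shown sit. Compound 2 alone gives a number, 6470 nM.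

Compound 4 `CC(=O)Nc1ccc(NC(=O)NCCCCC(c2ccc(F)cc2)c2ccc(F)cc2)cc1` differs from compound 3 in one place: acetyl in place of hydrogen on a nitrogen on an aromatic ring. In words, this is amino to acetamido, with acetyl in place of hydrogen on a nitrogen on an aromatic ring.

Among the measured compounds shown here, no measured step makes this exact change, so the evidence is indirect. Two steps that exchange the group on the aromatic carbon are beyond the scatter: nitro in place of methyl gave an at least 3.0-fold lower number from compound 1 to compound 2 (0.49 log units; beyond the scatter), and amino in place of nitro gave an at least 3.0-fold higher number from compound 2 to compound 3 (0.49 log units; beyond the scatter). The third, amino in place of methyl, gave a step that the two limits leave unreadable from compound 1 to compound 3. Of these groups only nitro brought a value off the limit, and the acetamido group has not been tested in this set. No shift beyond the scatter is therefore expected, and the result may again be only a limit. The step expected in this assay is a number no higher from compound 3 to compound 4 (the limit leaves the size open). For compound 4 the estimate is 20000 nM, with an expected range from 8000 nM to 50000 nM.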

Compound 4, half-maximal inhibitory concentration: > 20000 nM
Compound 4 gave a limit, no number; the forecaster's own chance of this, stated with the estimate: 60%; the middle value sits exactly at the limit.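

In this assay compound 4 gives > 20000 nM, which is a limit and not a number, so acetamido joins methyl and amino among the groups on this aromatic carbon that leave the value at the limit: the limit of > 20000 nM in this assay, at which 3 of the 4 values shown sit.

Acetamido in place of nitro gives an at least 3.0-fold higher number from compound 2 to compound 4 (0.49 log units; beyond the scatter), and nitro stays the only one of the four groups shown that brings a value off the limit. The steps from compound 3 and from compound 1 to compound 4 cannot be read, as both ends of each are limits, so acetyl on the amino nitrogen shows no change that can be sized.

Going by these compounds, how far compound 3 and compound 4 each lie beyond the limit stays open, and with it whether acetyl changes anything at this position. Also open, on these data alone, is whether the number of compound 2 belongs to nitro alone, or whether a nitrile or a trifluoromethyl group on the same aromatic carbon would also come off the limit.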